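From methylsulfanyl to cyano in a small series

The source may hold more compounds than are shown below. What is called first, only, known or untested is meant among the compounds shown, and "the series" means these compounds.

Measured so far in a functional assay on MDA-MB-231 cells (Homo sapiens) for inhibition, read by MTT assay, with a stated time of 48 h; a lower number here means a stronger inhibitor, a higher number a weaker inhibitor
- compound 1 `CS(=O)(=O)c1ccc(-c2nc3ccccn3c2Sc2ccccc2)cc1` gives 72700 nM
- compound 2 `CSc1ccc(-c2nc3ccccn3c2Sc2ccccc2)cc1` gives 23500 nM

Going by the values given here, compound 2 holds the lower of the two numbers so far, and compound 1 is its only neighbour. Next is compound 3 `N#Cc1ccc(-c2nc3ccccn3c2Sc2ccccc2)cc1` which differs from compound 2 at a single spot, para to a large group cyano in place of methylsulfanyl on an aromatic carbon and the rest of the structure is unchanged.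

Among the compounds with values here, one measured step bears on this change, and it sits at the same place: a 3.1-fold lower number from compound 1 to compound 2 (0.49 log units; beyond the scatter) is modest and beyond the scatter. Within the data shown here, it is the only comparison available, and in it the methylsulfanyl compound has the lower number. Two values set no trend, and nothing yet shows how cyano fares in this assay. A modest rise of similar or smaller size is therefore expected, though a drop cannot be ruled out. The expected step is a 2.1-fold higher number from compound 2 to compound 3 (0.33 log units; beyond the scatter) and remains tentative. The estimate for compound 3 is an expected value (50000 nM) within an expected range (18000 nM to 120000 nM).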

Compound 3, half-maximal inhibitory concentration: 17800 nM
Estimate against measurement, compound 3: 2.8-fold (0.45 log units) above; the measured number lies below the stated range.
By their numbers in this assay, from the lowest: compounds 3 and 2 (each within the scatter of the next); then compound 1.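

In this assay the change from methylsulfanyl to cyano, on an aromatic carbon para to a large group, gives a 1.3-fold lower number from compound 2 to compound 3 (0.12 log units; within the scatter) and so does not separate the two groups. The comparison with methylsulfonyl gives a 4.1-fold lower number from compound 1 to compound 3 (0.61 log units; beyond the scatter) and adds a second step beyond the scatter at this position, leaving compound 1 as the weakest of the three. Among these three groups, methylsulfonyl is therefore the one that stands apart, whereas the single earlier step could not show whether methylsulfanyl or methylsulfonyl was the exception, and no supporting data on these compounds account for the pattern.

From the compounds shown here alone, it remains open whether an amine, a carboxylic acid or a longer thioether chain at the same position would give a number beyond the scatter from those of compound 2 and compound 3. Going by these compounds, it is also open whether the close match between cyano and methylsulfanyl would persist with a change elsewhere on the shared core, or in cells other than those of this assay.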